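A Phenyl on the Five-Membered Ring: Stability Outlook

The compounds below may be only part of what the source reports. "The series", "measured", "known", "first", "only" and "open" are said of these compounds alone.

compound 1 `CCCCCCCCc1ccc(OCC(=O)Cn2cnnn2)cc1`: 22%
compound 2 `CCCCCCCCc1ccc(OCC(=O)Cn2nnc(C(=O)OC)n2)cc1`: < 5% (a limit of the assay, not a number)

Going by the values given here, in an ADME assay on S9 fraction from liver (Rattus norvegicus) for metabolic stability, read by LC-MS, using NADPH, with a stated time of 30 min (on this read-out higher numbers stand for a more stable compound and lower numbers for a less stable compound), compound 1 gives 22%, the only plain number in this small set. Compound 2 shows < 5%, which is a limit of the assay rather than a measured number. Among the compounds with values here, the single measured step, a number at least 17 percentage points lower from compound 1 to compound 2 (beyond the scatter), therefore ends at the limit (the limit of < 5% in this assay, at which 1 of the 2 values shown sits), so its true size is only known as a minimum.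

Compound 3 `CCCCCCCCc1ccc(OCC(=O)Cn2nnnc2-c2ccccc2)cc1` differs from compound 1 in one place: phenyl in place of hydrogen on an aromatic carbon. This is a different group at a different ring position than in compound 2, so the measured step does not apply directly; it only shows that altering this ring can lower the fraction remaining. A smaller downward step from compound 1 is expected, a number 7 percentage points lower from compound 1 to compound 3 (within the scatter), within or near the scatter. Compound 3 is thus estimated at 15%, ranging from 5% to 30%.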

Compound 3, percent of the compound remaining: 36%
The estimate for compound 3 lay 21 percentage points below the measured number, and the stated range ends below it.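

Within this assay, phenyl in place of hydrogen on an aromatic carbon gives a number 14 percentage points higher from compound 1 to compound 3 (beyond the scatter). Changing the five-membered ring therefore does not always lower the percent remaining, since this change, made on the carbon between two ring nitrogen atoms, moves the number in the opposite direction to the change that leads to compound 2. Nothing shown here explains why compound 3 keeps more of its starting amount.

From the compounds shown here alone, it remains open whether a methyl group or an amine on this same aromatic carbon would move the number in the same direction as phenyl. Going by these compounds, it is also open whether a phenyl carrying a fluorine atom or a carboxylic acid would keep this gain, or whether the gain would survive a shorter chain in the rest of the molecule.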